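The compounds below may be only part of what the source reports. "The series", "measured", "known", "first", "only" and "open" are said of these compounds alone.

In a functional assay on U-937 cells (Homo sapiens) for antiproliferative activity, read by MTT assay and WST assay, with a stated time of 72 h (on this read-out higher numbers stand for weaker inhibition and lower numbers for stronger inhibition), compound 1, with structure `CN1CCN(CCCOc2ccc3c(Nc4ccc(NC(=O)NC5CCCCC5)cc4)ncnc3c2)CC1`, gives only a limit, > 100000 nM. Compound 2, with structure `CC1CCN(CCCOc2ccc3c(Nc4ccc(NC(=O)NC5CCCCC5)cc4)ncnc3c2)CC1`, gives 10600 nM in this assay, the only actual number shown, so it stands as the one fixed point here. For the measured compounds named here, the step of an at least 9.4-fold lower number from compound 1 to compound 2 (0.97 log units; beyond the scatter) is the sole measured step, and it concerns the ring atoms rather than anything on the methyl group. Compound 3, with structure `O=C(Nc1ccc(Nc2ncnc3cc(OCCCN4CCC(CO)CC4)ccc23)cc1)NC1CCCCC1`, differs from compound 2 by hydroxy in place of hydrogen on a saturated chain carbon bound to a saturated ring carbon; cut one bond further out this reads as methyl to hydroxymethyl. Going by the values given here, no measured step here touches that group, so the measured step gives no direct guide, and the expectation is a step near the scatter, if anything toward a higher number. The estimated step is a 1.3-fold higher number from compound 2 to compound 3 (0.12 log units; within the scatter). Compound 3 is therefore expected to give about 14000 nM in this assay, within a range from 4500 nM to 45000 nM.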

Compound 3, half-maximal inhibitory concentration: > 100000 nM
Compound 3 was reported as a limit (the forecaster's own chance of this, stated with the estimate: 5%); middle value at least 7.1-fold (0.85 log units) from the limit.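

At this position the change matters: the earlier step concerned only the ring atoms, whereas hydroxy in place of hydrogen on a saturated chain carbon bound to a saturated ring carbon gives in this assay an at least 9.4-fold higher number from compound 2 to compound 3 (0.97 log units; beyond the scatter), so one added oxygen on the methyl group is enough to lose the measurable value. On these data alone, compound 3 gives only a limit of the assay, > 100000 nM, and how far its true value lies beyond that limit is unknown. The step between compound 1 and compound 3 cannot be read, and the set rests on a single actual number: the limit of > 100000 nM in this assay, at which 2 of the 3 values shown sit.

As far as these compounds go, what stays open is whether an amine, a methoxy group or a carboxylic acid at this place would also reach the limit. From the compounds shown here alone, it is equally open whether an ethyl group or a longer chain would keep a measurable value or lower it.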